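From ethoxy to methoxy on a shared core

This account rests on a few compounds, and the source may have more. Where it says the series, first, only, none or still open, it means among the compounds named here.

In a functional assay on DU-145 cells (Homo sapiens) for cytotoxicity, read by sulforhodamine B assay, with a stated time of 3 days (a lower number here means that less compound is needed, a higher number that more compound is needed for the effect), compound 3 (`CCOc1c(-c2occ(C)c2CO)ccc2c1CCCC2(C)C`) gives 17.5 uM. Compound 1 (`CCOCc1c(C)coc1-c1ccc2c(c1OC)CCCC2(C)C`) gives 17.7 uM, and compound 2 (`COC(=O)c1c(C)coc1-c1ccc2c(c1OC)CCCC2(C)C`) gives 33.5 uM. Compound 3 lies within the scatter of both, so these numbers set it apart from neither.

Compound 4 (`COc1c(-c2occ(C)c2CO)ccc2c1CCCC2(C)C`) is related to compound 3 by a single change: hydrogen in place of methyl on a saturated chain carbon bound to an oxygen on an aromatic ring. This places hydrogen in place of methyl on a saturated chain carbon bound to an oxygen on an aromatic ring, turning ethoxy to methoxy.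

Going by the values given here, no measured step tests this change directly. Among the compounds with values here, the only single-place step available is a 1.9-fold higher number from compound 1 to compound 2 (0.28 log units; within the scatter), which replaces ethoxymethyl with methoxycarbonyl on an aromatic carbon. It is a different change, and it bears only indirectly, as a sign that a one-place change in this small set stayed within the scatter. On that limited evidence, no shift beyond the scatter is expected in this assay, and no direction is favoured. The expected step is a 1.0-fold higher number from compound 3 to compound 4 (0.01 log units; within the scatter). Compound 4 is estimated at 18 uM, with an expected range from 9 uM to 36 uM.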

Compound 4, concentration for half-maximal effect: 21.7 uM
Compound 4: middle estimate off by 1.2-fold (0.08 log units), on the low side; the range from low to high includes it.
By their numbers in this assay, from the lowest: compounds 3, 1, 4 and 2 (each within the scatter of the next).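

In this assay, going by these compounds alone, the ethoxy to methoxy change gives a 1.2-fold higher number from compound 3 to compound 4 (0.09 log units; within the scatter), the first direct reading at this position, and taking methyl off the saturated chain carbon bound to an oxygen on an aromatic ring does not separate the two compounds. Compound 4 also widens the picture at the other site of change, on an aromatic carbon: hydroxymethyl in place of methoxycarbonyl gives a 1.5-fold lower number from compound 2 to compound 4 (0.19 log units; within the scatter), and hydrogen in place of ethyl on an oxygen on a saturated carbon gives a 1.2-fold higher number from compound 1 to compound 4 (0.09 log units; within the scatter), so ethoxymethyl, methoxycarbonyl and hydroxymethyl all stand within the scatter of one another on the methoxy core. No independent evidence bears on why these changes leave the numbers so close.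

The compounds shown leave open whether a longer chain such as butoxy, or a chain ending in an amine, on that oxygen would move the number beyond the scatter, and whether a carboxylic acid in place of hydroxymethyl on the aromatic carbon would do so. They also leave open whether the two sites act independently, since ethoxy appears here only with hydroxymethyl.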